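From 4-fluorobenzyl to 2,6-difluorobenzyl

A few compounds are considered here, and "the series" means these few. Any claim that something is new, unique, unknown or untested is made for them only; others in the source may bear on it.

In a functional assay on HepG2 cells (Homo sapiens) for antiproliferative activity, read by MTT assay, with a stated time of 48 h (a higher number here means a weaker inhibitor, a lower number a stronger inhibitor), compound 1 `Fc1ccc(CSc2nnc(-c3cnccn3)s2)c(F)c1` gives 9630 nM and compound 2 `Fc1ccc(CSc2nnc(-c3cnccn3)n2-c2ccccc2)cc1` gives 10100 nM, so these two values lie within the scatter of each other. Compound 3 `Fc1cccc(F)c1CSc1nnc(-c2cnccn2)n1-c1ccccc1` carries 2,6-difluorophenyl in place of the 4-fluorophenyl of compound 2, on a saturated chain carbon bound to a sulfur (2,6-difluorophenyl in place of 4-fluorophenyl on a saturated chain carbon bound to a sulfur). Within the data shown here, no step between measured compounds informs this change, so no shift beyond the scatter is expected in this assay, in either direction. The expected step is a 1.1-fold lower number from compound 2 to compound 3 (0.05 log units; within the scatter). The estimate for compound 3 is 9000 nM, with an expected range of 4000 nM to 20000 nM.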

Compound 3, half-maximal inhibitory concentration: 22600 nM
Compound 3: the middle estimate sits 2.5-fold (0.40 log units) below what was measured; the whole stated range lies below it.
By their numbers in this assay, from the lowest: compounds 1 and 2 (each within the scatter of the next); then compound 3.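

In this assay, the group on a saturated chain carbon bound to a sulfur can shift the number beyond the scatter: 2,6-difluorophenyl in place of 4-fluorophenyl gives a 2.2-fold higher number from compound 2 to compound 3 (0.35 log units; beyond the scatter) and so weakens the inhibitor modestly. This direction rests on a single pair of compounds. No measurement here explains the shift.

As far as these compounds go, whether the loss follows the number of fluorines or where they stand on the ring stays open. So does the reading for a 4-methoxybenzyl group or a longer chain on the sulfur.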